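A few compounds are considered here, and "the series" means these few. Any claim that something is new, unique, unknown or untested is made for them only; others in the source may bear on it.

Compound 3 `COc1c(Br)cccc1C(=O)Nc1ccc(Sc2nc3ccccc3s2)cc1` stands at a limit: in an assay for inhibition of HSP60/HSP10 (Homo sapiens), with a stated time of 60 min (on this read-out higher numbers stand for weaker inhibition and lower numbers for stronger inhibition), compound 3 gives > 100000 nM, which is a limit of the assay and not a number. Compound 1 `COc1ccc(Br)cc1C(=O)Nc1ccc(Sc2nc3ccccc3s2)cc1` in this assay gives > 100000 nM, likewise a limit. Compound 2 `O=C(Nc1ccc(Sc2nc3ccccc3s2)cc1)c1cc(Br)cc(Br)c1` gives > 100000 nM in this assay, again a limit. Compound 4 `O=C(Nc1ccc(Sc2nc3ccccc3s2)cc1)c1cccc(Br)c1O` differs from compound 3 by hydrogen in place of methyl on an oxygen on an aromatic ring, a methoxy to hydroxy change. Among the compounds with values here, the steps that bear on this change, a step that the two limits leave unreadable from compound 1 to compound 3 and a step that the two limits leave unreadable from compound 2 to compound 3, cannot be read from the two limits, nor can a step that the two limits leave unreadable from compound 1 to compound 2; all three values sit at the limit of > 100000 nM in this assay, at which 3 of the 3 values shown sit. Within the data shown here, no step of readable size is therefore at hand, and nothing beyond the scatter is expected. Compound 4 is estimated at 150000 nM in this assay, between 30000 nM and 1000000 nM, a step that the limit leaves unreadable from compound 3 to compound 4 that is expected to leave it at the limit.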

Compound 4, half-maximal inhibitory concentration: 26000 nM
Compound 4: middle estimate off by 5.8-fold (0.76 log units), on the high side, and the stated range ends above it.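

In this assay, within the data shown here, methoxy to hydroxy is the first change here with a readable effect, giving an at least 3.8-fold lower number from compound 3 to compound 4 (0.58 log units; beyond the scatter). The other two comparisons agree, with an at least 3.8-fold lower number from compound 2 to compound 4 (0.58 log units; beyond the scatter) and an at least 3.8-fold lower number from compound 1 to compound 4 (0.58 log units; beyond the scatter). All three steps start from a limit of the assay, so their true size stays unknown, and compound 4 alone has left that limit: the limit of > 100000 nM in this assay, at which 3 of the 4 values shown sit.

Going by these compounds, it remains open whether an amine in place of the hydroxy would give a similar step. On these data alone, it also remains open whether the hydroxy would do so with the bromine placed as in compound 1.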